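The compounds below may be only part of what the source reports. "The series", "measured", "known", "first", "only" and "open" are said of these compounds alone.

In an assay for inhibition of alpha-N-acetylgalactosaminidase (Gallus gallus), tested at 1000 uM (on this read-out lower numbers stand for less inhibition and higher numbers for more inhibition at the one concentration tested (going by the name of the read-out)), compound 1, `O=C(O)[C@H]1NC[C@H](O)[C@H](O)[C@H]1O`, gives 21%. Compound 2, `O=C(O)[C@@H]1NC[C@@H](O)[C@@H](O)[C@H]1O`, gives 8.2% in this assay, and compound 3, `O=C(O)[C@@H]1NCC=C[C@H]1O`, gives 3.2%. Compound 2 thus holds the second highest of the three numbers: its value and that of compound 3 lie within the scatter of each other, while the value of compound 1 stands beyond the scatter above it. Among the compounds with values here, the one measured step between compounds that differ in a single place is a number 12.8 percentage points lower from compound 1 to compound 2 (beyond the scatter), a modest fall that arises because of the fact that compounds 1 and 2 differ only in the configuration as drawn.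

Compound 4, `O=C(O)[C@@H]1NC[C@@H](O)[C@@H](O)[C@@H]1O`, has not yet been measured in this assay. It differs from compound 2 only as counted: the two compounds have the same atoms and bonds and differ only in configuration as drawn: 1 of 4 stereo elements differ; a stereocentre at a saturated ring carbon is drawn S in compound 2 and R in compound 4. The step from compound 1 to compound 2 is the only measured one that bears on such a change of configuration; it covered three stereo elements and moved the number by a modest amount. A change at one centre might move the number by a comparable or smaller amount, and its direction cannot be read from a single step, so no movement beyond the scatter is expected. Compound 4 is therefore estimated at 10%, between 0% and 28%. For compound 4 this means an expected step of a number 1.8 percentage points higher from compound 2 to compound 4 (within the scatter).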

Compound 4, a percentage reported as inhibition, at one concentration (the size of the read-out at that concentration, not a potency): 7.2%
For compound 4 the middle estimate is 2.8 percentage points above the measured one, and the stated range covers the measured number.
By their numbers in this assay, from the lowest: compounds 3, 4 and 2 (each within the scatter of the next); then compound 1.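

In this assay, the inversion of one saturated ring stereocentre gives a number 1 percentage points lower from compound 2 to compound 4 (within the scatter), so this single change of configuration has no effect that can be told from the scatter, and compound 2 and compound 4 cannot be placed in any order. The earlier compounds shown here showed only a change at three stereo elements at once, whereas the full mirror image now gives a number 13.8 percentage points lower from compound 1 to compound 4 (beyond the scatter), so the fall seen before also holds with all four stereo elements changed, and the further inversion adds nothing that can be read. With atoms and bonds unchanged, the configuration as drawn is the only thing that can account for this fall: the fact that compounds 1 and 4 differ only in the configuration as drawn

The compounds shown leave open which of the stereocentres, inverted alone in compound 1, would carry the fall, and whether one centre suffices or several must change together. They also leave open how the number in this assay would respond if a primary amide or a hydroxymethyl group took the place of the carboxylic acid on the shared core.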